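The compounds below may be only part of what the source reports. "The series", "measured", "known", "first", "only" and "open" are said of these compounds alone.

Of the compounds shown here, three have been measured in a functional assay on cardiac atrium for agonist activity at histamine H2 receptor (Cavia porcellus); a lower number here means a smaller maximal response, a higher number a larger maximal response. Compound 1 `Cc1nc(N)sc1CCCNC(=N)NC(=O)CC(C)C1CCCCC1` gives 74% in this assay, compound 2 `Cc1nc(N)sc1CCCNC(=N)NC(=O)C[C@H](C)c1ccccc1` gives 87%, and compound 3 `C[C@@H](CC(=O)NC(=N)NCCCc1c[nH]cn1)c1ccccc1` gives 102%. Compound 2 therefore stands second highest of the three: compound 1 lies below it and compound 3 above it, both by margins beyond the scatter. The two measured steps are a number 13 percentage points higher from compound 1 to compound 2 (beyond the scatter) on putting 1-phenylethyl in place of 1-cyclohexylethyl on a saturated chain carbon bound to a carbonyl carbon, and a number 15 percentage points higher from compound 2 to compound 3 (beyond the scatter) on putting 1H-imidazol-4-yl in place of 2-amino-4-methyl-1,3-thiazol-5-yl on a saturated chain carbon, three bonds along the chain from an amine nitrogen.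

Compound 4 `Cc1nc(N)sc1CCCNC(=N)NC(=O)C[C@@H](C)c1ccccc1` has not yet been measured in this assay. It differs from compound 2 as follows: the two compounds have the same atoms and bonds; at least one stereo element is drawn with a configuration in one of them and without one in the other: 1 of 2 stereo elements differ; a stereocentre at a saturated chain carbon is drawn S in compound 2 and R in compound 4. Neither measured step bears on this change, since each of them swaps one group for another and neither touches a stereocentre. Among the compounds with values here, no measured pair shows what an inversion of this kind does to the largest response, so the expectation rests on the assumption that the response stays where compound 2 left it, with a wide margin on either side. Compound 4 is thus expected to show about the same maximal response, the estimated step being a number 2 percentage points lower from compound 2 to compound 4 (within the scatter). Compound 4 is expected to give 85% in this assay, within a range from 65% to 100%.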

Compound 4, largest response reached (Emax), in percent of the reference or control that the assay uses: 73%
For compound 4 the middle estimate is 12 percentage points above the measured one; measured number inside the range.
By their numbers in this assay, from the lowest: compounds 4 and 1 (each within the scatter of the next); then compound 2; then compound 3.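

With atoms and bonds unchanged, the configuration at this saturated chain carbon turns out to matter for the maximal response in this assay, with a number 14 percentage points lower from compound 2 to compound 4 (beyond the scatter) on going from S to R, a step of about the same size as the two group swaps seen earlier. The gain seen on putting 1-phenylethyl in place of 1-cyclohexylethyl therefore holds only for the S form, since the R form gives a number 1 percentage points lower from compound 1 to compound 4 (within the scatter), and compound 1 itself carries no drawn configuration at this carbon. The contrast between compound 2 and compound 4 thus rests on stereochemistry alone, and one point of the drawings has to be kept in mind when reading it: the fact that one of compounds 2 and 4 is drawn with a defined configuration and the other without, at the place where they differ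

The compounds shown leave open whether the same inversion changes the response in the same direction when 1H-imidazol-4-yl takes the place of 2-amino-4-methyl-1,3-thiazol-5-yl, and how the two separate configurations of 1-cyclohexylethyl compare. They also leave open whether the preference for S persists with a larger group at this carbon, such as 1-phenylpropyl, or with a methoxy group on the phenyl ring.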